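Flipping one stereocentre of compound 2

The compounds below may be only part of what the source reports. "The series", "measured", "known", "first", "only" and "open" are said of these compounds alone.

Compound 1 `CC(C)CC1n2cncc2CN(Cc2ccc(OC(F)(F)F)cc2)S1(=O)=O`: 0.117 h
Compound 2 `C[C@@H](c1ccc(Cl)cc1)N1Cc2cncn2C(C[C@@H](O)c2ccccc2)S1(=O)=O`: 0.4 h
Compound 3 `CC(C)CC1n2cncc2CN([C@H](C)c2ccc(Cl)cc2)S1(=O)=O`: 0.0833 h

In an in vitro ADME assay on microsomes from liver (Homo sapiens) for metabolic stability (a higher number here means that the compound lasts longer, a lower number that the compound disappears faster), compound 2 has 0.4 h as the highest number of the three, and compound 1 and compound 3 both lie lower by more than the usual scatter. Compound 4 `C[C@@H](c1ccc(Cl)cc1)N1Cc2cncn2C(C[C@H](O)c2ccccc2)S1(=O)=O` differs from compound 2 by the two compounds have the same atoms and bonds; at least one stereo element is drawn with a configuration in one of them and without one in the other: 1 of 3 stereo elements differ; a stereocentre at a saturated chain carbon is drawn R in compound 2 and S in compound 4 only: a stereocentre at a saturated chain carbon is drawn R in compound 2 and S in compound 4. Among the measured compounds shown here, no measured pair here shows what such a change does, so the estimate starts from compound 2 and its 0.4 h as the closest measured structure. The expected no change at the digits printed from compound 2 to compound 4 (within the scatter) stays within the scatter, with neither direction favoured. Compound 4 is expected at 0.4 h (0.17 h to 0.9 h).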

Compound 4, half-life: 0.25 h
The estimate for compound 4 lay 1.6-fold (0.20 log units) above the measured number; the range from low to high includes it.
By their numbers in this assay, from the lowest: compounds 3 and 1 (each within the scatter of the next); then compounds 4 and 2 (each within the scatter of the next).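

In this assay, a 1.6-fold lower number from compound 2 to compound 4 (0.20 log units; within the scatter), so whether this saturated chain carbon is drawn R or S makes no difference that can be told from the scatter. Neither compound 1 nor compound 3 offers such a comparison, and this pair isolates the stereocentre with all atoms and bonds unchanged. One caution applies to this reading: the fact that one of compounds 2 and 4 is drawn with a defined configuration and the other without, at the place where they differ

Left open is what an amine or a methoxy group in place of the hydroxyl on this carbon would do in this assay.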